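The source may hold more compounds than are shown below. What is called first, only, known or untested is meant among the compounds shown, and "the series" means these compounds.

Compound 1 `Cc1cn(C2CCN(Cc3cccc(Oc4cccc(F)c4)c3)CC2)c(=O)[nH]c1=O` is a thymine-bearing piperidine whose aryl ether carries a 3-fluorophenyl group. In an ADME assay on MRC5 cells (Homo sapiens) for cytotoxicity, read by fluorescence and resazurin assay, with a stated time of 3 days (on this read-out lower numbers stand for stronger inhibition and higher numbers for weaker inhibition), compound 1 gives > 64000 nM, which is a limit of the assay rather than a measured number. Compound 2 `Cc1cn(C2CCN(Cc3cncc(Oc4cc(Cl)cc(Cl)c4)c3)CC2)c(=O)[nH]c1=O` is a close relative with a pyridine in place of the central benzene. In this assay compound 2 also gives > 64000 nM, again a limit. Compound 3 `Cc1cn(C2CCN(Cc3cccc(Oc4ccc(O)cc4)n3)CC2)c(=O)[nH]c1=O` gives "not determined" (no result reported) in this assay, so no number is known for it. So compound 1 stands at the limit of > 64000 nM in this assay, at which 2 of the 3 values shown sit, with no compound showing a true number to compare against. Compound 4 `Cc1cn(C2CCN(Cc3cccc(Oc4ccc(Cl)c(C(F)(F)F)c4)c3)CC2)c(=O)[nH]c1=O` differs from compound 1 by 4-chloro-3-(trifluoromethyl)phenyl in place of 3-fluorophenyl on an oxygen on an aromatic ring. For the measured compounds named here, with no measured step, the step of a number no higher from compound 1 to compound 4 (the limit leaves the size open) is expected to be none beyond the scatter. Compound 4 is expected to give about 64000 nM, between 20000 nM and 200000 nM.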

Compound 4, half-maximal inhibitory concentration: 5280 nM
For compound 4 the middle estimate is 12-fold (1.08 log units) above the measured one; measured number below the stated range.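

In this assay, the group on this oxygen on an aromatic ring can clearly change the read-out: 4-chloro-3-(trifluoromethyl)phenyl in place of 3-fluorophenyl gives an at least 12-fold lower number from compound 1 to compound 4 (1.08 log units; beyond the scatter). For the compounds shown here, compound 4 therefore supplies the first true number in this set, showing that this series can reach measurable cytotoxicity. From the compounds shown here alone, the full size of the step stays unknown because compound 1 gives only a limit: the limit of > 64000 nM in this assay, at which 2 of the 4 values shown sit.

Whether the chlorine or the trifluoromethyl group accounts for the step remains open. So does the effect of an amine or a carboxylic acid on this ring.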